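Extending the Ester Chain on the Shared Core

The source may hold more compounds than are shown below. What is called first, only, known or untested is meant among the compounds shown, and "the series" means these compounds.

Compound 1 `O=C(Nc1cc(C(F)(F)F)cc(C(F)(F)F)c1)c1cnc(Cl)nc1C(F)(F)F` gives 50 nM in an assay on Jurkat cells for inhibition of nuclear factor NF-kappa-B p105 subunit (Homo sapiens); on this read-out lower numbers stand for stronger inhibition and higher numbers for weaker inhibition. Compound 2 `NC(=O)c1cc(NC(=O)c2cnc(Cl)nc2C(F)(F)F)cc(C(F)(F)F)c1` gives 5000 nM in this assay, and compound 3 `CCOC(=O)c1cc(NC(=O)c2cnc(Cl)nc2C(F)(F)F)cc(C(F)(F)F)c1` gives 280 nM. Compound 3 thus stands second highest of the three numbers; its nearest neighbour is compound 1, with a 5.6-fold higher number from compound 1 to compound 3 (0.75 log units; beyond the scatter), and its furthest is compound 2, with an 18-fold lower number from compound 2 to compound 3 (1.25 log units; beyond the scatter). Compound 4 `CCCCCCOC(=O)c1cc(NC(=O)c2cnc(Cl)nc2C(F)(F)F)cc(C(F)(F)F)c1` carries butyl in place of hydrogen on a saturated chain carbon, two bonds along the chain from an oxygen next to a carbonyl group. Neither measured step touches the ester chain itself: the two steps into compound 3 replace the whole group on an aromatic carbon or exchange ethoxy for amino on a carbonyl carbon. Lengthening the chain has no precedent among these compounds, so only a small shift is anticipated. Compound 4 is therefore expected to show a 1.1-fold higher number from compound 3 to compound 4 (0.03 log units; within the scatter). Compound 4 is estimated at 300 nM, within 100 nM to 1000 nM.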

Compound 4, half-maximal inhibitory concentration: 620 nM
Estimate against measurement, compound 4: 2.1-fold (0.32 log units) below; low and high end bracket the measured number.
By their numbers in this assay, from the lowest: compound 1; then compound 3; then compound 4; then compound 2.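

Lengthening the ester chain from ethoxy to hexyloxy is not neutral in this assay: it moves the number up by a modest but real step (a 2.2-fold higher number from compound 3 to compound 4 (0.35 log units; beyond the scatter)), so this chain position responds to added butyl. The hexyloxy ester still reads better than the amide (an 8.1-fold lower number from compound 2 to compound 4 (0.91 log units; beyond the scatter)) but falls further behind the trifluoromethyl group (a 12-fold higher number from compound 1 to compound 4 (1.09 log units; beyond the scatter)). Nothing available here accounts for this shift. On these data alone, what a butoxy ester, a longer chain or a carboxylic acid would give on this carbonyl carbon remains open.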